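The source may hold more compounds than are shown below. What is called first, only, known or untested is meant among the compounds shown, and "the series" means these compounds.

Working notes on the series. Compound 1 `COc1cc(C(=O)C2Sc3nnc(-c4cc(OC)c(OC)c(OC)c4)n3NC2c2ccco2)cc(OC)c1OC`, compound 2 `COc1cc(-c2nnc3n2NC(c2cccs2)C(C(=O)c2ccccc2)S3)cc(OC)c1OC` and compound 3 `COc1cc(-c2nnc3n2NC(c2ccco2)C(C(=O)c2ccccc2)S3)cc(OC)c1OC` share one core and differ only in the aryl on the carbonyl and in the five-membered ring on the saturated ring carbon. In a functional assay on PC-3 cells (Homo sapiens) for cytotoxicity, read by MTT assay, with a stated time of 48 h (on this read-out lower numbers stand for stronger inhibition and higher numbers for weaker inhibition), compound 1 gives 52200 nM, compound 2 gives 86300 nM and compound 3 gives 64300 nM. Compound 3 thus holds the second highest of the three numbers, with compound 1 nearest and compound 2 furthest, both gaps within the scatter. Compound 4 `COc1cc(-c2nnc3n2NC(c2ccco2)C(C(=O)c2ccc(C(F)(F)F)cc2)S3)cc(OC)c1OC` differs from compound 3 in one place: trifluoromethyl in place of hydrogen on an aromatic carbon. The measured step that bears on this sits at the same carbonyl aryl, a 1.2-fold higher number from compound 1 to compound 3 (0.09 log units; within the scatter), where exchanging a fully substituted ring for a bare one left the number within the scatter. The other step, a 1.3-fold lower number from compound 2 to compound 3 (0.13 log units; within the scatter), concerns the saturated ring carbon and also stayed within the scatter. A single trifluoromethyl on the carbonyl aryl is therefore expected to give no step beyond the scatter in this assay, in either direction. For compound 4 a value of 55000 nM is estimated, with a range from 22000 nM to 140000 nM. That expectation amounts to a step of a 1.2-fold lower number from compound 3 to compound 4 (0.07 log units; within the scatter).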

Compound 4, half-maximal inhibitory concentration: 77500 nM
Estimate against measurement, compound 4: 1.4-fold (0.15 log units) below; the measured number falls inside the stated range.
By their numbers in this assay, from the lowest: compounds 1, 3, 4 and 2 (each within the scatter of the next).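

In this assay, the first substituent on the bare phenyl of the carbonyl gives a 1.2-fold higher number from compound 3 to compound 4 (0.08 log units; within the scatter) with trifluoromethyl para to a large group, so this position accepts that group without a step beyond the scatter. Read against the fully substituted ring, 4-(trifluoromethyl)phenyl in place of 3,4,5-trimethoxyphenyl gives a 1.5-fold higher number from compound 1 to compound 4 (0.17 log units; within the scatter) and likewise stays within the scatter, which places all three carbonyl aryl groups shown, with furan-2-yl held fixed, within the scatter of one another. No measurement at hand offers an explanation for this flat reading at the carbonyl aryl.

The compounds shown leave open whether an amine or a carboxylic acid on this phenyl ring would also stay within the scatter, and whether trifluoromethyl at another place on the ring would read the same. For the compounds shown here, they also leave open whether the carbonyl aryl behaves alike with thiophen-2-yl on the saturated ring carbon, where compound 2 is the only example and carries a plain phenyl on the carbonyl.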